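Compound 4: piperidin-1-yl for pyrrolidin-1-yl on the chain

The source may report more compounds than this note shows. Statements on the series, on what has been measured and on what is new or still open speak of the compounds shown alone.

In a functional assay on MCF7 cells (Homo sapiens) for cytotoxicity, read by MTT assay, with a stated time of 72 h (on this read-out lower numbers stand for stronger inhibition and higher numbers for weaker inhibition), compound 1 `COc1ncc(-c2ccc3nc(NC(=O)N4CCCC4)nn3c2)cc1NS(=O)(=O)c1ccc(F)cc1` gives 1660 nM and compound 2 `COc1ncc(-c2ccc3nc(NC(=O)N(C)C)nn3c2)cc1NS(=O)(=O)c1ccc(F)cc1` gives 1560 nM, which is a 1.1-fold lower number from compound 1 to compound 2 (0.03 log units; within the scatter). Compound 3 `COc1ncc(-c2ccc3nc(NC(=O)NCCN4CCCC4)nn3c2)cc1NS(=O)(=O)c1ccc(F)cc1` has the lowest number of the three at 380 nM. The steps leading to it are a 4.4-fold lower number from compound 1 to compound 3 (0.64 log units; beyond the scatter) and a 4.1-fold lower number from compound 2 to compound 3 (0.61 log units; beyond the scatter), each placing (2-(pyrrolidin-1-yl)ethyl)amino on the carbonyl carbon.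

Compound 4 `COc1ncc(-c2ccc3nc(NC(=O)NCCN4CCCCC4)nn3c2)cc1NS(=O)(=O)c1ccc(F)cc1` differs only at the end of that chain: piperidin-1-yl in place of pyrrolidin-1-yl on a saturated chain carbon, two bonds along the chain from an amide-type nitrogen. In words, this is piperidin-1-yl in place of pyrrolidin-1-yl on a saturated chain carbon, two bonds along the chain from an amide-type nitrogen. Among the measured compounds shown here, no measured step makes this exact change. The closest exchange of end groups, a 1.1-fold lower number from compound 1 to compound 2 (0.03 log units; within the scatter), sits on the carbonyl carbon and offers only weak guidance, but it gives no reason to expect a large shift. The two larger steps concern gaining the chain, which compound 4 retains.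

The expected step is small, not beyond the scatter: a 1.1-fold higher number from compound 3 to compound 4 (0.02 log units; within the scatter). For compound 4 the estimated value in this assay is 400 nM, with an expected range of 180 nM to 900 nM.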

Compound 4, half-maximal inhibitory concentration: 200 nM
Beside the measured number, compound 4's estimate is 2.0-fold (0.30 log units) above it; the measured number falls inside the stated range.
By their numbers in this assay, from the lowest: compounds 4 and 3 (each within the scatter of the next); then compounds 2 and 1 (each within the scatter of the next).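

In this assay the end of the chain accepts a six-membered ring as readily as a five-membered one, and the exchange of pyrrolidin-1-yl for piperidin-1-yl on this saturated chain carbon gives no separation beyond the scatter (a 1.9-fold lower number from compound 3 to compound 4 (0.28 log units; within the scatter)). The advantage of carrying the chain is therefore not tied to pyrrolidin-1-yl, since compound 4 also stands clear of the two compounds without the chain (a 7.8-fold lower number from compound 2 to compound 4 (0.89 log units; beyond the scatter); an 8.3-fold lower number from compound 1 to compound 4 (0.92 log units; beyond the scatter)). No measurement at hand accounts for the size of any of these steps.

The compounds shown leave open how far the chain end can vary, for instance with morpholin-4-yl or an open dimethylamino group in place of piperidin-1-yl. They also leave open whether a longer chain carrying piperidin-1-yl would hold these values.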